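Cytotoxicity on Dog Kidney Cells: From Amine to Thioether

The compounds below may be only part of what the source reports. "The series", "measured", "known", "first", "only" and "open" are said of these compounds alone.

Measured compounds:
- compound 1, `CCCCOc1ccc(CN(Cc2ccc(C(C)(C)C)cc2)Cc2cc3cc(C)ccc3[nH]c2=O)cc1`: in a toxicity assay on MDCK cells (Canis lupus familiaris) for cytotoxicity, read by crystal violet staining, with a stated time of 48 h (a lower number here means that less compound is tolerated, a higher number that more compound is tolerated), compound 1 gives > 5000 nM, which is a limit of the assay and not a number.
- compound 2, `Cc1ccc2[nH]c(=O)c(CN(Cc3ccc(N(C)C)cc3)Cc3ccc(C(C)(C)C)cc3)cc2c1`: in this assay compound 2 gives > 5000 nM, also a limit of the assay.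

Among the measured compounds shown here, compound 2 therefore stands at a limit rather than at a measured number, and the same holds for its only measured neighbour, as the limit of > 5000 nM in this assay, at which 2 of the 2 values shown sit, shows. The step that the two limits leave unreadable from compound 1 to compound 2 cannot be read, since two limits set no size on it. Compound 3, `Cc1ccc2[nH]c(=O)c(CN(Cc3ccc(SC(F)F)cc3)Cc3ccc(C(C)(C)C)cc3)cc2c1`, differs from compound 2 in one place: (difluoromethyl)sulfanyl in place of dimethylamino on an aromatic carbon. For the measured compounds named here, no measured step bears directly on this change, and the single measured step is itself unreadable. Compound 3 is expected to sit at the limit as well, so the expected step that the limit leaves unreadable from compound 2 to compound 3 is none beyond the scatter. The estimate for compound 3 in this assay is 8000 nM, with a range from 4000 nM to 30000 nM.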

Compound 3, half-maximal cytotoxic concentration: > 5000 nM
Compound 3: only a limit was reported; the forecaster's own chance of this, stated with the estimate: 80%; the middle value lies beyond the limit too.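

Compound 3 gives > 5000 nM in this assay and this is a limit of the assay, not a number. Among the compounds shown here, compound 1 and compound 2 also sit at limits, so no step among the three can be read. Where each compound's true half-maximal cytotoxic concentration lies, and whether these group changes shift it, stays open.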